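Dropping the acyl group from compound 1

This account rests on a few compounds, and the source may have more. Where it says the series, first, only, none or still open, it means among the compounds named here.

Measured compounds:
compound 1, `COc1ccccc1N1CCN(CCNc2c(C(=O)C(C)C)c(-c3ccccc3)nn(C)c2=O)CC1`, gives 0.18 nM in an assay on isolated protein for binding affinity to Alpha-1A adrenergic receptor (Homo sapiens), read by radioligand binding; a lower number here means a stronger inhibitor, a higher number a weaker inhibitor
compound 2, `COc1ccccc1N1CCN(CCCNc2c(C(C)=O)c(-c3ccccc3)nn(C)c2=O)CC1`, gives 1.51 nM in this assay
compound 3, `CC(=O)c1c(-c2ccccc2)nn(C)c(=O)c1NCCN1CCN(c2ccccc2F)CC1`, gives 0.32 nM in this assay

Compound 1 has the lowest number of the three in this assay. Its nearest neighbour is compound 3, whose number is higher by an amount that lies within the scatter, so these two cannot be ranked against each other. Compound 2 stands furthest away, with a number higher than that of compound 1 by an amount beyond the scatter.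

Compound 4, `COc1ccccc1N1CCN(CCNc2cc(-c3ccccc3)nn(C)c2=O)CC1`, is not yet measured. It differs from compound 1 in one place: hydrogen in place of isopropylcarbonyl on an aromatic carbon. Going by the values given here, each of the three measured compounds carries a carbonyl-bearing group at this position of the shared core, so there is no measured step that shows what its loss does. The expectation is therefore uncertain. Because compound 1 gives 0.18 nM and the removed group is present in every measured compound, the step of an 11-fold higher number from compound 1 to compound 4 (1.05 log units; beyond the scatter) is expected to go toward a higher number, of a size beyond the scatter, though a step within the scatter cannot be ruled out. Compound 4 is accordingly estimated at 2 nM, with a range from 0.3 nM to 15 nM.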

Compound 4, inhibition constant: 0.22 nM
Compound 4: the middle estimate sits 9.1-fold (0.96 log units) above what was measured, outside the stated range (below it).
By their numbers in this assay, from the lowest: compounds 1, 4 and 3 (each within the scatter of the next); then compound 2.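

In this assay the exchange of isopropylcarbonyl for hydrogen on the aromatic carbon gives a 1.2-fold higher number from compound 1 to compound 4 (0.09 log units; within the scatter) and therefore provides no basis for ranking the two compounds. Going by these compounds alone, every earlier compound carried a carbonyl-bearing group at this position, so only this pair shows that, with the rest of compound 1 kept in place, a number as low as that of compound 1 does not require the isopropylcarbonyl group. The compounds shown offer no measured explanation for this result.

On these data alone, it remains open whether the position tolerates other groups in the same way: an amine, a carboxylic acid or a nitrile on this aromatic carbon could leave the number within the scatter or move it well beyond. As far as these compounds go, it is also open whether hydrogen in place of the acetyl group would give a similarly small step with the longer chain of compound 2 or the fluorine-bearing phenyl group of compound 3.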